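This account rests on a few compounds, and the source may have more. Where it says the series, first, only, none or still open, it means among the compounds named here.

Cytotoxicity across the series is read in an ADME assay on L929 cells (Mus musculus) for cytotoxicity, read by resazurin assay, with a stated time of 72 h; on this read-out lower numbers stand for stronger inhibition and higher numbers for weaker inhibition. Compound 1 `COc1cccc(C(=O)/C=C/c2ccccc2)c1` gives 5.7 ug/mL in this assay, and compound 3 `OB1OCc2ccc(/C=C/C(O)c3ccccc3)cc21` gives 2.88 ug/mL. Compound 2 `O=C(/C=C/c1ccc2c(c1)B(O)OC2)c1ccco1` returns only a limit of this assay, > 10 ug/mL. Among the three values shown, compound 2 thus sits at the limit rather than at a number, as noted in the limit of > 10 ug/mL in this assay, at which 1 of the 3 values shown sits. Compound 4 `O=C(/C=C/c1ccc2c(c1)B(O)OC2)c1ccc(Cl)cc1` is not yet measured in this assay; it carries 4-chlorophenyl in place of furan-2-yl on a carbonyl carbon. Among the compounds with values here, no two measured compounds differ in a single place, so no measured step guides the comparison. In this assay the change is expected to push the value of compound 4 downward into the measurable range, though not clearly beyond the scatter. The expected step is an at least 1.4-fold lower number from compound 2 to compound 4 (0.15 log units; that floor lies within the scatter). Compound 4 is estimated at 7 ug/mL, between 3 ug/mL and 14 ug/mL.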

Compound 4, half-maximal inhibitory concentration: > 10 ug/mL
Compound 4: only a limit was reported; the forecaster's own chance of this, stated with the estimate: 35%; middle value at least 1.4-fold (0.15 log units) from the limit.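

In this assay, within the data shown here, compound 2 and compound 4 both stand only as limits, so no step between them can be read: the limit of > 10 ug/mL in this assay, at which 2 of the 4 values shown sit. On these data alone, how far 4-chlorophenyl and furan-2-yl on a carbonyl carbon differ in cytotoxicity remains open.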